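The compounds below may be only part of what the source reports. "The series", "measured", "known", "first", "only" and "open" are said of these compounds alone.

Series notes. Compound 1 `Cc1ccc(C(=O)n2c(-c3cn(-c4ccccc4)nc3-c3ccc(F)cc3)nc3ccccc32)cn1`, compound 2 `Cc1cccc(C(=O)n2c(-c3cn(-c4ccccc4)nc3-c3ccc(F)cc3)nc3ccccc32)c1` and compound 3 `O=C(c1ccccc1)n1c(-c2cn(-c3ccccc3)nc2-c2ccc(F)cc2)nc2ccccc21` share one core and differ only in the aryl group on the carbonyl carbon. In an ADME assay on HEK-293T cells (Homo sapiens) for cytotoxicity, read by MTT assay, with a stated time of 24 h (on this read-out lower numbers stand for higher toxicity in this test and higher numbers for lower toxicity in this test), compound 1 gives 137000 nM, compound 2 gives 148000 nM and compound 3 gives 180000 nM. Compound 3 holds the highest of the three numbers, yet the steps of a 1.1-fold higher number from compound 1 to compound 2 (0.03 log units; within the scatter), a 1.3-fold higher number from compound 1 to compound 3 (0.12 log units; within the scatter) and a 1.2-fold higher number from compound 2 to compound 3 (0.09 log units; within the scatter) all stay within the scatter, so the three sit at one level. Compound 4 `O=C(c1cccnc1)n1c(-c2cn(-c3ccccc3)nc2-c2ccc(F)cc2)nc2ccccc21` carries pyridin-3-yl in place of phenyl on a carbonyl carbon. Within the data shown here, the closest precedent is the exchange of 6-methylpyridin-3-yl for phenyl on the carbonyl carbon, a 1.3-fold higher number from compound 1 to compound 3 (0.12 log units; within the scatter), which was flat. For compound 4 the expected step is therefore a 1.1-fold lower number from compound 3 to compound 4 (0.04 log units; within the scatter), nothing beyond the scatter. Compound 4 is estimated at 165000 nM, range 85000 nM to 320000 nM.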

Compound 4, half-maximal cytotoxic concentration: 216000 nM
For compound 4 the middle estimate is 1.3-fold (0.12 log units) below the measured one, within the range that was stated.
By their numbers in this assay, from the lowest: compounds 1, 2, 3 and 4 (each within the scatter of the next).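

Pyridin-3-yl without a methyl sits at the same level as the other three aryl groups on the carbonyl carbon in this assay: a 1.2-fold higher number from compound 3 to compound 4 (0.08 log units; within the scatter), a 1.5-fold higher number from compound 2 to compound 4 (0.16 log units; within the scatter) and a 1.6-fold higher number from compound 1 to compound 4 (0.20 log units; within the scatter). Taking away the methyl also reads alike with and without the ring nitrogen: the same change on two cores in this assay, a 1.2-fold higher number (0.09 log units; within the scatter) from compound 2 to compound 3 and a 1.6-fold higher number (0.20 log units; within the scatter) from compound 1 to compound 4, 1.3-fold (0.11 log units) apart, within the scatter of two such steps At this position, carbon or nitrogen in the ring and the presence of a methyl give no step beyond the scatter.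

Open, as far as these compounds go, is whether an amine, a carboxylic acid or a longer alkyl chain on this aryl group would move the number beyond the scatter.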